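A few compounds are considered here, and "the series" means these few. Any claim that something is new, unique, unknown or untested is made for them only; others in the source may bear on it.

Measured so far in a functional assay on DLD-1 cells (Homo sapiens) for antiproliferative activity, read by CellTiter-Glo, with a stated time of 72 h; a higher number here means a weaker inhibitor, a lower number a stronger inhibitor:
Compound 1, `CC1CCN(C2CCN(S(=O)(=O)c3cccc(-c4ccccc4F)c3)CC2)CC1`: 10 nM
Compound 2, `CC1CCN(C2CCN(S(=O)(=O)c3cccc(-c4ccc(Cl)cc4)c3)CC2)CC1`: 15 nM

Among the compounds with values here, compound 2 carries the higher of the two numbers, with compound 1 as its only neighbour, yet the step of a 1.5-fold higher number from compound 1 to compound 2 (0.18 log units; within the scatter) lies within the scatter, so the two cannot be ordered. Compound 3, `Cc1ccc(-c2cccc(S(=O)(=O)N3CCC(N4CCC(C)CC4)CC3)c2)cc1`, differs from compound 2 by methyl in place of chloro on an aromatic carbon. Within the data shown here, the one measured step, a 1.5-fold higher number from compound 1 to compound 2 (0.18 log units; within the scatter), exchanges one ring substituent for another without leaving the scatter, and no measured pair tests methyl against chloro. The writer therefore expects no step beyond the scatter, no change at the digits printed from compound 2 to compound 3 (within the scatter), and estimates compound 3 at 15 nM, between 6 nM and 40 nM.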

Compound 3, half-maximal inhibitory concentration: 11 nM
Compound 3: middle estimate off by 1.4-fold (0.13 log units), on the high side; measured number inside the range.
By their numbers in this assay, from the lowest: compounds 1, 3 and 2 (each within the scatter of the next).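

In this assay, methyl in place of chloro, on an aromatic carbon para to a large group, gives a 1.4-fold lower number from compound 2 to compound 3 (0.13 log units; within the scatter), so this exchange cannot be told apart from no change. The 4-methylphenyl group likewise cannot be separated from the 2-fluorophenyl group, with a 1.1-fold higher number from compound 1 to compound 3 (0.04 log units; within the scatter), and all three compounds remain unordered. No evidence is available to explain this result. The compounds shown leave open whether an amine, a carboxylic acid or a longer chain at this place would stay within the scatter of these three.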